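Swapping the aryl group on a fused thiazole core

The compounds below may be only part of what the source reports. "The series", "measured", "known", "first", "only" and "open" are said of these compounds alone.

Within the data shown here, compound 1 `C=C(Br)C(=O)Nc1cccc(-c2cn3nc(-c4ccc(F)cc4)sc3n2)c1` is tested in a functional assay on L1210 cells (Mus musculus) for inhibition, read by cell counting, with a stated time of 2 days (a higher number here means a weaker inhibitor, a lower number a stronger inhibitor), where compound 1 gives 250 nM, the only plain number in the set. Compound 2 `COc1ccc(-c2nn3cc(-c4cccc(N)c4)nc3s2)cc1`, which lacks the bromoacrylamide and carries a methoxyphenyl group, reaches only the limit of the assay, and in this assay compound 2 gives >= 250000 nM. Compound 3 `C=C(Br)C(=O)Nc1cccc(-c2cn3nc(-c4cccs4)sc3n2)c1` keeps the bromoacrylamide and the shared core of compound 1 and differs in one place only: thiophen-2-yl in place of 4-fluorophenyl on an aromatic carbon. Among the measured compounds shown here, no measured pair in the set shows what such a swap does, so the size of the step is open; the expectation is a small change, if any, within the usual scatter, with the aryl group exchanged but the rest of compound 1 untouched. Compound 3 is estimated at 300 nM, between 100 nM and 1000 nM, a step of a 1.2-fold higher number from compound 1 to compound 3 (0.08 log units; within the scatter) from the measured value.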

Compound 3, half-maximal inhibitory concentration: 170 nM
Beside the measured number, compound 3's estimate is 1.8-fold (0.25 log units) above it; the measured number falls inside the stated range.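

Among these compounds, this exchange gives the first measured pair at this position: in this assay, the swap gives a 1.5-fold lower number from compound 1 to compound 3 (0.17 log units; within the scatter), so compound 1 and compound 3 cannot be told apart. With the bromoacrylamide and the shared core kept, a five-membered thiophen-2-yl ring therefore serves as well as the six-membered 4-fluorophenyl ring in this assay, and the fluorine is not needed to keep the inhibition seen in compound 1. Nothing among the measurements shown gives a reason for this result.

On these data alone, both groups compared here are uncharged aromatic rings, so it stays open how an amine, a carboxylic acid or a longer chain would behave at this place. As far as these compounds go, compound 2 gives >= 250000 nM, a limit of the assay and not a number, and it differs from compound 1 in more than one place, so what each difference contributes also stays open.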